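The source may report more compounds than this note shows. Statements on the series, on what has been measured and on what is new or still open speak of the compounds shown alone.

Measured so far: compound 1 `COc1ccc(CNc2nc3cc(N)cc(N)c3nc2-c2ccccc2)cc1OC` with 30200 nM; compound 2 `Nc1cc(N)c2nc(-c3ccccc3)c(NCc3ccc(F)cc3)nc2c1` with < 100000 nM.

In a functional assay on SK-MEL-2 cells (Homo sapiens) for inhibition, read by sulforhodamine B assay, with a stated time of 48 h (on this read-out lower numbers stand for stronger inhibition of growth and higher numbers for weaker inhibition of growth), compound 1 gives 30200 nM. For compound 2, this assay reports only a limit, < 100000 nM, so compound 2 stands at the limit of < 100000 nM in this assay, at which 1 of the 2 values shown sits, rather than at a number. The step that the limit leaves unreadable from compound 1 to compound 2 is thus not readable.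

Compound 3 `COc1ccc(CNc2nc3cc(N)cc(N)c3nc2-c2ccccc2)cc1` differs from compound 2 by methoxy in place of fluoro on an aromatic carbon. For the measured compounds named here, the only step that bears on this, a step that the limit leaves unreadable from compound 1 to compound 2, gives no size, so no direction beyond the scatter is expected in this assay. The expected step that the limit leaves unreadable from compound 2 to compound 3 is therefore set small. Compound 3 is estimated at 40000 nM, between 15000 nM and 100000 nM.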

Compound 3, concentration for total growth inhibition: 28800 nM
The estimate for compound 3 lay 1.4-fold (0.14 log units) above the measured number; low and high end bracket the measured number.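

In this assay, hydrogen in place of one methoxy, taking 3,4-dimethoxyphenyl to 4-methoxyphenyl, gives a 1.0-fold lower number from compound 1 to compound 3 (0.02 log units; within the scatter), so the second methoxy makes no readable difference here. Compound 2 stands only at a limit, so its steps to the other two compounds cannot be read: the limit of < 100000 nM in this assay, at which 1 of the 3 values shown sits.

As far as these compounds go, whether 4-fluorobenzyl and 4-methoxybenzyl differ therefore stays open. Also open, from the compounds shown here alone, is whether an amine or a carboxylic acid on this aromatic ring, or a longer chain in place of the benzyl, would move the number beyond the scatter.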